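A methyl-to-chloro step starting from compound 2

The source may report more compounds than this note shows. Statements on the series, on what has been measured and on what is new or still open speak of the compounds shown alone.

Compound 1, `CN(C(=O)CCCc1ccccc1)c1nc2ccccc2c(=O)s1`, has "not determined" (no result reported) in an assay on mitochondria (strain Sprague-Dawley) for inhibition of Amine oxidase [flavin-containing] B (Rattus norvegicus), read by fluorescence and Amplex Red, with stated times of 30 min and 45 min (on this read-out lower numbers stand for stronger inhibition and higher numbers for weaker inhibition), so it brings no number.
Compound 2, `Cc1ccc2nc(NC(=O)CCCc3ccccc3)sc(=O)c2c1`, gives 325 nM in this assay.
Compound 3, `Cc1sc2nc(NC(=O)CCCc3ccccc3)sc(=O)c2c1C`, gives 26.6 nM in this assay.

Among the two compounds with a number, compound 2 has the higher one, so the weaker inhibition. Compound 3, which has a different core, sits well below it, and that gap is beyond the usual scatter of repeated measurements. Compound 1 adds no number to the comparison.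

Compound 4, `O=C(CCCc1ccccc1)Nc1nc2ccc(Cl)cc2c(=O)s1`, keeps the core of compound 2 and changes only one point: chloro in place of methyl on an aromatic carbon.

Among the measured compounds shown here, no pair of measured compounds differs in exactly this way, so nothing here shows how large such a swap tends to be. On this basis the step in this assay from compound 2 is expected to be small, leaning toward a lower number and plausibly not beyond the scatter. The estimated step is a 1.6-fold lower number from compound 2 to compound 4 (0.21 log units; within the scatter). Compound 4 is therefore estimated at 200 nM, with a range from 60 nM to 700 nM.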

Compound 4, half-maximal inhibitory concentration: > 10000 nM
Compound 4: only a limit was reported; the forecaster's own chance of this, stated with the estimate: 5%; at least 50-fold (1.69 log units) between middle value and limit.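

Among the compounds shown here, this position on the six-membered aromatic ring turns out to be highly sensitive, which the earlier compounds could not show: in this assay, chloro in place of methyl gives an at least 30-fold higher number from compound 2 to compound 4 (1.48 log units; beyond the scatter). For compound 4, the value of > 10000 nM is a limit of the assay and not a number. The swap leaves the counts of heavy atoms, hydrogen-bond donors and hydrogen-bond acceptors unchanged, yet it separates a compound with a measured value from one with only a limit, so the full size of the step stays unknown: the limit of > 10000 nM in this assay, at which 1 of the 4 values shown sits.

The compounds shown leave open whether the step reflects the arrival of chloro or the loss of methyl, a question that fluoro, methoxy or plain hydrogen at this position could help settle. Going by these compounds, it also remains open whether the same swap would have a similar effect on the core of compound 3.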